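The compounds below may be only part of what the source reports. "The series", "measured", "known", "first", "only" and "open" are said of these compounds alone.

Working notes on the hydroxamic acid series.

Within the data shown here, compound 1 `CN(O)/C=C\C(=O)c1ccc([N+](=O)[O-])cc1` is the weaker of the two compounds measured so far in an assay on RBL-1 cells for inhibition of Polyunsaturated fatty acid 5-lipoxygenase (Rattus norvegicus); on this read-out lower numbers stand for stronger inhibition and higher numbers for weaker inhibition: compound 1 gives 1500 nM. Its nearest neighbour on the numbers is compound 2 `O=C(/C=C\N(O)c1ccccc1)c1ccc2ccccc2c1`, which in this assay gives 810 nM; the two values lie within the usual scatter of each other, so no order between compound 1 and compound 2 can be read from them.

Compound 3 `COc1ccc(C(=O)/C=C\N(C)O)cc1` is the next compound awaiting measurement. It differs from compound 1 by one change: methoxy in place of nitro on an aromatic carbon. Among the measured compounds shown here, no step between measured compounds covers this change, so the expectation rests on the two values alone. The step from compound 1 to compound 3 in this assay is expected to be a 1.3-fold lower number from compound 1 to compound 3 (0.10 log units; within the scatter), small and not clearly beyond the scatter in either direction. Compound 3 is accordingly expected to give about 1200 nM in this assay, with a range from 400 nM to 4000 nM.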

Compound 3, half-maximal inhibitory concentration: 6000 nM
Estimate against measurement, compound 3: 5.0-fold (0.70 log units) below; the measured number lies above the stated range.
By their numbers in this assay, from the lowest: compounds 2 and 1 (each within the scatter of the next); then compound 3.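

In this assay, methoxy in place of nitro on the aromatic carbon para to a group of 7 heavy atoms gives a 4.0-fold higher number from compound 1 to compound 3 (0.60 log units; beyond the scatter) and so lies beyond the scatter. Among these compounds, this is the first single change whose size can be read, and it shows that the group at this position matters for inhibition, with the nitro compound of this pair giving the lower number. The step rests on this one pair alone, and no measurement on hand accounts for it.

The compounds shown leave open where chloro, an amine or a carboxylic acid at this position would fall relative to nitro and methoxy. They also leave open whether the same change would give a step of similar size on the core of compound 2.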